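A few compounds are considered here, and "the series" means these few. Any claim that something is new, unique, unknown or untested is made for them only; others in the source may bear on it.

Compound 1 `CCOc1cc(C(Nc2ccc3cnccc3c2)C(=O)NS(=O)(=O)c2ccccc2)ccc1OC(C)C` gives > 5000 nM in an assay on isolated protein for inhibition of Trypsin (Homo sapiens); on this read-out lower numbers stand for stronger inhibition and higher numbers for weaker inhibition.
Compound 2 `CCOc1cc(C(Nc2ccc3cnccc3c2)C(=O)NS(=O)(=O)c2ccccc2S(C)(=O)=O)ccc1OC(C)C` gives > 5000 nM in this assay.
Compound 3 `CCOc1cc(C(Nc2ccc3cnccc3c2)C(=O)NS(=O)(=O)c2ccc(S(C)(=O)=O)cc2)ccc1OC(C)C` gives > 5000 nM in this assay.

Each of these values is a limit of the assay rather than a number, so compound 3 stands at the same limit as the other two and cannot be ordered against them. Compound 4 `CCOc1cc(C(Nc2ccc3cnccc3c2)C(=O)NS(=O)(=O)c2ccccc2S(=O)(=O)CC)ccc1OC(C)C` has not been measured; it differs from compound 3 by 2-(ethylsulfonyl)phenyl in place of 4-(methylsulfonyl)phenyl on a sulfonyl sulfur. The measured steps that bear on this change are a step that the two limits leave unreadable from compound 1 to compound 2, a step that the two limits leave unreadable from compound 1 to compound 3 and a step that the two limits leave unreadable from compound 2 to compound 3, and none of them has a readable size because of the limit of > 5000 nM in this assay, at which 3 of the 3 values shown sit. With every measured value at that limit, compound 4 is expected to return a limit as well, so the estimated step that the limit leaves unreadable from compound 3 to compound 4 is itself not expected to be readable. Compound 4 is estimated at 10000 nM, within a range from 5000 nM to 40000 nM.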

Compound 4, inhibition constant: > 5000 nM
Compound 4: a limit, no number (the forecaster's own chance of this, stated with the estimate: 85%); the middle value does not contradict the limit.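

Going by these compounds alone, compound 4 also returns a limit rather than a number in this assay, so no step from compound 1, compound 2 or compound 3 to compound 4 can be read: the limit of > 5000 nM in this assay, at which 4 of the 4 values shown sit. The compounds shown leave open how strongly any of them inhibits, and whether changing the group on the sulfonyl sulfur makes any difference in this assay.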